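Aryl selenocyanate and diselenide carbamates: growth inhibition notes

The compounds below may be only part of what the source reports. "The series", "measured", "known", "first", "only" and "open" are said of these compounds alone.

Measured compounds:
compound 1 `C=CCOC(=O)Nc1ccc([Se]C#N)cc1` 15000 nM
compound 2 `CCOC(=O)Nc1ccc([Se][Se]c2ccc(NC(=O)OCC)cc2)cc1` 9900 nM
compound 3 `O=C(Nc1ccc([Se][Se]c2ccc(NC(=O)OCc3ccccc3)cc2)cc1)OCc1ccccc1` 5200 nM

In a functional assay on MCF7 cells (Homo sapiens) for cytotoxicity, read by MTT assay, with a stated time of 72 h (a higher number here means a weaker inhibitor of growth, a lower number a stronger inhibitor of growth), compound 1 gives 15000 nM, the highest of the three numbers. Compound 2 lies within the scatter of compound 1, while compound 3 sits beyond it with the lowest number of the set. Going by the values given here, no pair among the measured compounds differs in a single place, so no measured step is available to guide the next change.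

Compound 4 `CCCCOC(=O)Nc1ccc([Se]C#N)cc1` differs from compound 1 only at the carbamate chain: propyl in place of vinyl on a saturated chain carbon bound to an oxygen next to a carbonyl group. Among the compounds with values here, with no comparable step among the measured compounds, the expectation is a step from compound 1 to compound 4 of a 1.3-fold lower number from compound 1 to compound 4 (0.10 log units; within the scatter), which is not beyond the scatter. Compound 4 is therefore estimated at 12000 nM, within 5000 nM to 30000 nM.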

Compound 4, concentration for 50% growth inhibition: 6600 nM
Beside the measured number, compound 4's estimate is 1.8-fold (0.26 log units) above it; low and high end bracket the measured number.
By their numbers in this assay, from the lowest: compounds 3, 4, 2 and 1 (each within the scatter of the next, the first and the last beyond it).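

In this assay, going by these compounds alone, the carbamate chain is a place that responds: the change from allyl to butyl gives a 2.3-fold lower number from compound 1 to compound 4 (0.36 log units; beyond the scatter), the first step that can be read. This single step both removes the double bond and lengthens the chain, so the two changes cannot be separated. No available evidence bears on the reason for the shift.

Still open, on these data alone, is whether a longer chain such as hexyl, or an amine on the chain, moves the number further. Also open, as far as these compounds go, is how a selenocyanate and a diselenide compare when they carry the same carbamate chain.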